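The compounds below may be only part of what the source reports. "The series", "measured", "known", "first", "only" and "open" are said of these compounds alone.

In a functional assay on MCF7 cells (Homo sapiens) for inhibition, read by sulforhodamine B assay (a lower number here means a stronger inhibitor, a higher number a weaker inhibitor), three compounds sharing one core have been measured. Compound 1 `O=C1C=C(Nc2cccc(F)c2)C(=O)c2c1nc1n2[C@H]2OC[C@@H](O)[C@H]2OC1`, with a 3-fluorophenyl group on the amine nitrogen, gives 5500 nM. Compound 3 `COc1ccc(NC2=CC(=O)c3nc4n(c3C2=O)[C@H]2OC[C@@H](O)[C@H]2OC4)cc1`, with a 4-methoxyphenyl group in that place, gives 5420 nM. The step between these two is a 1.0-fold lower number from compound 1 to compound 3 (0.01 log units; within the scatter), so they stand level with each other. Compound 2 `COc1ccccc1NC1=CC(=O)c2nc3n(c2C1=O)[C@H]1OC[C@@H](O)[C@H]1OC3`, with a 2-methoxyphenyl group there, is reported only as a limit, > 4000 nM. Its comparison gives a step that the limit leaves unreadable from compound 1 to compound 2.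

Compound 4 `CCCN(CCC)C1=CC(=O)c2nc3n(c2C1=O)[C@H]1OC[C@@H](O)[C@H]1OC3` changes far more than a substituent on the phenyl ring: dipropylamino in place of (4-methoxyphenyl)amino on a double-bonded ring carbon. In words, dipropylamino stands in place of (4-methoxyphenyl)amino on a double-bonded ring carbon, so the ring and the hydrogen-bond donor on the nitrogen both go.

Going by the values given here, only one readable step bears on this, a 1.0-fold lower number from compound 1 to compound 3 (0.01 log units; within the scatter), and it merely swaps one substituted phenyl group for another. Among the compounds with values here, it shows that the number stayed put through that swap, but no measured step removes the ring. No step beyond the scatter is therefore expected in this assay, with no direction favoured and only modest confidence. The expected change is a 1.0-fold higher number from compound 3 to compound 4 (0.01 log units; within the scatter). Compound 4 is estimated at 5500 nM, with an expected range of 1800 nM to 16000 nM.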

Compound 4, half-maximal inhibitory concentration: > 16000 nM
Compound 4: only a limit was reported (the forecaster's own chance of this, stated with the estimate: 30%); middle value at least 2.9-fold (0.46 log units) from the limit.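

In this assay compound 4 is reported only as a limit, > 16000 nM. Even so, its steps can be read: the change gives an at least 2.9-fold higher number from compound 3 to compound 4 (0.47 log units; beyond the scatter), and an at least 2.9-fold higher number from compound 1 to compound 4 (0.46 log units; beyond the scatter), so compound 4 is a weaker inhibitor than both, while the steps that involve compound 2 cannot be read. This position on the double-bonded ring carbon therefore does respond to what is attached to it: swapping one substituted phenyl group for another gave a 1.0-fold lower number from compound 1 to compound 3 (0.01 log units; within the scatter), whereas dipropylamino in place of the phenyl-bearing amine pushes the number beyond the scatter.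

That one change removes the aromatic ring and the hydrogen on the nitrogen together and brings in two propyl chains, so the compounds shown cannot say which of these events matters. Propylamino, which carries a chain but keeps the hydrogen on the nitrogen, and N-methyl-N-phenylamino, which keeps the ring but loses that hydrogen, would pull these apart.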